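A few compounds are considered here, and "the series" means these few. Any claim that something is new, unique, unknown or untested is made for them only; others in the source may bear on it.

Measured compounds:
compound 1 `N#Cc1cnc(NCc2cnccc2C(F)(F)F)cc1N[C@H]1C[C@H](O)C1` — 96%
compound 2 `N#Cc1cnc(NCc2cnccc2C(F)(F)F)cc1NC[C@H]1C[C@@H](O)C1` — 84%

In an ADME assay on S9 fraction from liver (Homo sapiens) for metabolic stability, with a stated time of 1 h (on this read-out lower numbers stand for a less stable compound and higher numbers for a more stable compound), compound 1 gives 96% and compound 2 gives 84%. Among the measured compounds shown here, compound 2 holds the lowest of the two numbers known so far, and its only neighbour is compound 1, set apart by a number 12 percentage points lower from compound 1 to compound 2 (beyond the scatter). Compound 3 `N#Cc1cnc(NCc2cnccc2C(F)(F)F)cc1NC1CCOCC1` has not been measured. Against compound 2 it carries oxan-4-yl in place of (3-hydroxycyclobutyl)methyl on a nitrogen on an aromatic ring.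

For the measured compounds named here, only one measured step bears on this change, and only loosely: the step of a number 12 percentage points lower from compound 1 to compound 2 (beyond the scatter) concerns a different exchange on the same nitrogen and is of modest size. Going by the values given here, no measured pair shows an oxan-4-yl group or the loss of the hydroxyl-bearing ring directly. The change from compound 2 to compound 3 is therefore expected to move the number only slightly, if at all, and most likely upward, giving an expected a number 4 percentage points higher from compound 2 to compound 3 (within the scatter) in this assay. On that basis compound 3 is estimated at 88%, with a likely range from 74% to 97%.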

Compound 3, percent of the compound remaining: 91%
Beside the measured number, compound 3's estimate is 3 percentage points below it, and the stated range covers the measured number.
By their numbers in this assay, from the lowest: compounds 2, 3 and 1 (each within the scatter of the next, the first and the last beyond it).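

In this assay, the nitrogen on an aromatic ring also accepts oxan-4-yl, whose six-membered non-aromatic ring carries 0 hydrogen-bond donors, and the two new steps read a number 7 percentage points higher from compound 2 to compound 3 (within the scatter) and a number 5 percentage points lower from compound 1 to compound 3 (within the scatter). Compound 3 thus cannot be told apart from either hydroxycyclobutyl-bearing compound, even though the gap between those two lies beyond the scatter, so among these three compounds a hydrogen-bond donor on this substituent is not required for a number in this range. Nothing available explains this outcome.

The compounds shown leave open how a ring amine such as piperidin-4-yl, or a longer chain ending in a carboxylic acid, would read on this nitrogen. They also leave open which part of the exchange matters, since oxan-4-yl differs from each hydroxycyclobutyl-bearing group in more than one feature at once, and whether the same reading would hold with any other part of the shared core changed.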